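The source may report more compounds than this note shows. Statements on the series, on what has been measured and on what is new or still open speak of the compounds shown alone.

Working notes on the series. Compound 1 `O=C(C1=C(Nc2ccc(F)cc2)C(=O)N(CCCn2ccnc2)C1c1ccc(Br)cc1)c1ccccc1` gives 27400 nM in a functional assay on A549 cells (Homo sapiens) for antiproliferative activity, read by MTT assay, with a stated time of 72 h; on this read-out higher numbers stand for weaker inhibition and lower numbers for stronger inhibition. Compound 2 `O=C(C1=C(Nc2cccc(Br)c2)C(=O)N(CCCn2ccnc2)C1c1ccc(Br)cc1)c1ccccc1` gives 15800 nM in the same assay; the step of a 1.7-fold lower number from compound 1 to compound 2 (0.24 log units; within the scatter) is the only one measured so far, so compound 2 stands beside compound 1 within the scatter and no ordering between the two can be claimed.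

Compound 3 `O=C(C1=C(NCc2ccccc2)C(=O)N(CCCn2ccnc2)C1c1ccc(Br)cc1)c1ccccc1` is not yet measured. It differs from compound 2 by benzyl in place of 3-bromophenyl on an amine nitrogen. Within the data shown here, the one measured step, from compound 1 to compound 2, exchanged one six-membered aromatic ring of carbon only for another on that amine nitrogen and stayed within the scatter; no step in the set covers the exchange of an aryl for a benzyl group. On that basis no step beyond the scatter is expected in this assay, in either direction. Compound 3 is therefore estimated at 17000 nM, with a range from 6000 nM to 48000 nM. This estimate corresponds to an expected step of a 1.1-fold higher number from compound 2 to compound 3 (0.03 log units; within the scatter).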

Compound 3, half-maximal inhibitory concentration: 52800 nM
Estimate against measurement, compound 3: 3.1-fold (0.49 log units) below, outside the stated range (above it).
By their numbers in this assay, from the lowest: compounds 2, 1 and 3 (each within the scatter of the next, the first and the last beyond it).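

In this assay, among these compounds, this amine nitrogen position is the first to show a step beyond the scatter: benzyl in place of 3-bromophenyl gives a 3.3-fold higher number from compound 2 to compound 3 (0.52 log units; beyond the scatter), a modest change. Benzyl in place of 4-fluorophenyl gives a 1.9-fold higher number from compound 1 to compound 3 (0.28 log units; within the scatter), which stays within the scatter, so the reading of the benzyl exchange depends on the aryl group it is set against, and compound 1 cannot be separated from either of the other two. No measured evidence on the cause of this step is available.

The compounds shown leave open whether the step follows the loss of the bromine or the change from aryl to benzyl. Unsubstituted phenyl or 3-bromobenzyl on the same amine nitrogen would separate these two readings.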